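The compounds below may be only part of what the source reports. "The series", "measured", "known", "first", "only" and "open" are said of these compounds alone.

Measured so far in an ADME assay on Vero cells (Chlorocebus sabaeus) for cytotoxicity, read by MTT assay, with a stated time of 72 h; a higher number here means that more compound is tolerated, a lower number that less compound is tolerated:
- compound 1, `C=CCN(CC=C)C(=S)N/N=C(/C)c1ccccc1`, gives 229000 nM
- compound 2, `C/C(=N/NC(=S)N(Cc1ccccc1)Cc1ccccc1)c1ccccc1O`, gives 160000 nM
- compound 3, `C/C(=N/NC(=S)N(Cc1ccccc1)Cc1ccccc1)c1ccccc1`, gives 167000 nM

Compound 1 has the highest of the three numbers, yet its distances to compound 3 and to compound 2 both lie within the usual scatter, so the three measured compounds cannot be told apart here. Compound 4, `C=CCN(CC=C)C(=S)N/N=C(/C)c1ccccc1O`, has not yet been measured in this assay. It differs from compound 1 by a single change, (hydroxy in place of hydrogen on an aromatic carbon). The same change is already seen once among the measured compounds, between compound 3 and compound 2: hydroxy in place of hydrogen on an aromatic carbon. That step, a 1.0-fold lower number from compound 3 to compound 2 (0.02 log units; within the scatter), left the number essentially where it was. The difference between the core of compound 1 and the core of compound 3 is not broken down here. On that basis the step of a 1.0-fold lower number from compound 1 to compound 4 (0.02 log units; within the scatter) is expected to be small as well, because a 1.0-fold lower number from compound 3 to compound 2 (0.02 log units; within the scatter) showed no change for the same alteration. Compound 4 is therefore estimated at 220000 nM in this assay, with a likely range from 120000 nM to 400000 nM.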

Compound 4, half-maximal cytotoxic concentration: 216000 nM
For compound 4 the middle estimate is 1.0-fold (0.01 log units) above the measured one; the measured number falls inside the stated range.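

In this assay, hydroxy in place of hydrogen on an aromatic carbon gives a 1.1-fold lower number from compound 1 to compound 4 (0.03 log units; within the scatter), so compounds 1 and 4 cannot be told apart by their cell tolerance. The same change has now been seen on two cores, and the two results agree: the same change on two cores in this assay, a 1.0-fold lower number (0.02 log units; within the scatter) from compound 3 to compound 2 and a 1.1-fold lower number (0.03 log units; within the scatter) from compound 1 to compound 4, 1.0-fold (0.01 log units) apart, within the scatter of two such steps. Among the compounds shown here, this shows that, for this pair of cores, the outcome seen on one core also held on the other, but it rests on only two steps, neither of which rises above the scatter, so it shows a carry-over of no detectable effect rather than of a measurable shift, and it says nothing about any other core or any other kind of test.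

The compounds shown leave open whether a larger or different group on the same aromatic carbon, such as a methoxy group, an amine or a carboxylic acid, would also leave the number indistinguishable. They also leave open whether hydroxy would behave the same way on a core carrying longer chains in place of the allyl or benzyl groups.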